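A few compounds are considered here, and "the series" means these few. Any claim that something is new, unique, unknown or untested is made for them only; others in the source may bear on it.

Measured compounds:
compound 1 `c1ccc(-c2cn3ccnc3c(-c3ccc4ncn(C5CCCCC5)c4c3)n2)cc1`: 36.8%
compound 2 `c1cn2cc(-c3ccsc3)nc(-c3ccc4ncn(C5CCCCC5)c4c3)c2n1`: 6.35%

In a functional assay on 786-0 cells (Homo sapiens) for inhibition, read by sulforhodamine B assay, with a stated time of 48 h, tested at 10 uM (on this read-out higher numbers stand for more inhibition at the one concentration tested (going by the name of the read-out) and lower numbers for less inhibition), compound 1 gives 36.8% and compound 2 gives 6.35%. Among the measured compounds shown here, compound 2 stands lowest of the two numbers measured so far; its only neighbour is compound 1, and the pair is separated by the step of a number 30.5 percentage points lower from compound 1 to compound 2 (beyond the scatter). Compound 3 `Fc1ccccc1-c1cn2ccnc2c(-c2ccc3ncn(C4CCCCC4)c3c2)n1` has not yet been measured. It differs from compound 2 by 2-fluorophenyl in place of thiophen-3-yl on an aromatic carbon. For the measured compounds named here, the one measured step that bears on this change is a number 30.5 percentage points lower from compound 1 to compound 2 (beyond the scatter), in which phenyl gave way to thiophen-3-yl on the same aromatic carbon. Going by the values given here, the change to compound 3 reverses that swap and brings in a phenyl ring carrying a fluorine, so the step is expected to run upward and to be of roughly similar size, though the fluorine has no measured precedent and widens the uncertainty. For compound 3 the expected step is a number 23.7 percentage points higher from compound 2 to compound 3 (beyond the scatter). The estimate for compound 3 is 30%, with a range from 10% to 50%.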

Compound 3, a percentage reported as inhibition, at one concentration (the size of the read-out at that concentration, not a potency): 2.94%
For compound 3 the middle estimate is 27.1 percentage points above the measured one; the measured number lies below the stated range.
By their numbers in this assay, from the lowest: compounds 3 and 2 (each within the scatter of the next); then compound 1.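

In this assay, the 2-fluorophenyl group does not hold the level of the plain phenyl: a number 33.9 percentage points lower from compound 1 to compound 3 (beyond the scatter). The swap between the two substituted or hetero aryl groups gives a number 3.4 percentage points lower from compound 2 to compound 3 (within the scatter), so thiophen-3-yl and 2-fluorophenyl read alike despite their different ring size and atoms, and of the three compounds only compound 1 stands apart from the others, which makes this aromatic carbon sensitive to a change as slight as fluoro in place of hydrogen. Nothing measured here gives a reason for this sensitivity.

Open, as far as these compounds go, is whether the drop from compound 1 belongs to fluoro as such or to where it sits on the phenyl ring; a chloro or methoxy group on that ring, or fluoro on another of its carbons, would separate the two. Also open, from the compounds shown here alone, is whether any group on this aromatic carbon, such as a pyridine ring or a phenyl ring carrying an amine, can rise beyond the level of compound 1 in this assay.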